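Replacing a nitrophenyl ether by a dimethylphenyl ether

The source may hold more compounds than are shown below. What is called first, only, known or untested is meant among the compounds shown, and "the series" means these compounds.

Measured compounds:
Compound 1 `Cc1ccc(OCC(=O)N2CCN(c3ccc(C(F)(F)F)cc3[C@@H](N)CC(C)C)CC2)cc1` gives 4400 nM.
Compound 2 `CC(C)C[C@H](N)c1cc(C(F)(F)F)ccc1N1CCN(C(=O)COc2ccc([N+](=O)[O-])cc2)CC1` gives 3100 nM.

In an assay on HEK293 cells for displacement of a labelled ligand from Melanocortin receptor 4 (Homo sapiens) (on this read-out higher numbers stand for weaker inhibition and lower numbers for stronger inhibition), compound 2 sits within the scatter of compound 1, since a 1.4-fold lower number from compound 1 to compound 2 (0.15 log units; within the scatter). Compound 3 `Cc1ccc(OCC(=O)N2CCN(c3ccc(C(F)(F)F)cc3[C@@H](N)CC(C)C)CC2)c(C)c1` differs from compound 2 by 2,4-dimethylphenyl in place of 4-nitrophenyl on an oxygen on a saturated carbon. Among the measured compounds shown here, the only measured step that bears on this, a 1.4-fold lower number from compound 1 to compound 2 (0.15 log units; within the scatter), swapped a methyl for a nitro without a change beyond the scatter, and the added methyl in compound 3 has no measured counterpart here. Compound 3 is therefore expected to show a 1.3-fold higher number from compound 2 to compound 3 (0.11 log units; within the scatter), no change beyond the scatter. Compound 3 is estimated at 4000 nM, within 1500 nM to 11000 nM.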

Compound 3, inhibition constant: 4000 nM
For compound 3 middle estimate and measured number coincide at the digits printed, and the stated range covers the measured number.
By their numbers in this assay, from the lowest: compounds 2, 3 and 1 (each within the scatter of the next).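

In this assay, the swap of 4-nitrophenyl for 2,4-dimethylphenyl on this oxygen gives a 1.3-fold higher number from compound 2 to compound 3 (0.11 log units; within the scatter), so a ring with no hydrogen-bond acceptors reads the same as one carrying them. The added methyl alone gives a 1.1-fold lower number from compound 1 to compound 3 (0.04 log units; within the scatter), so this position has so far shown no change beyond the scatter. Nothing measured here explains this flat result. Still open, as far as these compounds go, is whether an amine or a carboxylic acid on this ring, or a longer chain in place of a methyl, would shift the number beyond the scatter.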